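Bromo to cyano on a fused two-ring core

This account rests on a few compounds, and the source may have more. Where it says the series, first, only, none or still open, it means among the compounds named here.

Compound 2 `CC(C)n1nc(-c2ccc3oc(N)nc3c2)c2c(Br)nc(N)nc21` was tested in a physicochemical assay for solubility, read by HPLC, in phosphate buffer, measured as kinetic solubility, with a stated time of 24 h, at 20 degrees C, at pH 7.4, tested at 100 uM (a lower number here means a less soluble compound, a higher number a more soluble compound), and compound 2 gives 4000 nM. Among the results shown, compound 2 stands as the only compound with a full number; the other result is a limit. Compound 1 `CC(C)n1nc(-c2ccc3oc(N)nc3c2)c2c(F)nc(N)nc21` differs from compound 2 only by fluoro in place of bromo, and in this assay compound 1 gives < 1000 nM, which is a limit of the assay and not a number (the limit of < 1000 nM in this assay, at which 1 of the 2 values shown sits). Among the measured compounds shown here, the single measured step, an at least 4.0-fold higher number from compound 1 to compound 2 (0.60 log units; beyond the scatter), is the only guide. Compound 3 `CC(C)n1nc(-c2ccc3oc(N)nc3c2)c2c(C#N)nc(N)nc21` takes the change one stage further: cyano in place of bromo on an aromatic carbon. For the measured compounds named here, no measured pair exchanges bromo for cyano, so the halogen step an at least 4.0-fold higher number from compound 1 to compound 2 (0.60 log units; beyond the scatter) bears on it only loosely, showing that altering the group at this carbon can move the number at least modestly. For compound 3 the expected step is small, a 1.3-fold lower number from compound 2 to compound 3 (0.12 log units; within the scatter), since nothing shown points clearly either way. Compound 3 is estimated at 3000 nM, with a likely range from 800 nM to 12000 nM.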

Compound 3, solubility: < 1000 nM
Compound 3 was reported as a limit (the forecaster's own chance of this, stated with the estimate: 25%); middle value at least 3.0-fold (0.47 log units) away from the limit.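

In this assay, the change of bromo to cyano on this aromatic carbon gives an at least 4.0-fold lower number from compound 2 to compound 3 (0.60 log units; beyond the scatter), so a second, different replacement at this position now has a measured effect. With the earlier step from fluoro to bromo, this places bromo as the only group shown at this carbon that gives a full number, while the two other groups shown do not; this holds for these three compounds only. The value for compound 3 is a limit of the assay and not a number, and with compound 1 also at a limit, the step between these two cannot be read, so fluoro and cyano cannot be ordered against each other: the limit of < 1000 nM in this assay, at which 2 of the 3 values shown sit.

The compounds shown leave open whether bromo is unusual at this carbon or whether other groups, such as chloro, methyl, an amine or a carboxylic acid, would also give a full number. They also leave open where the true values of compound 1 and compound 3 lie behind their limits, and so how large the effect of leaving bromo really is.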